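The compounds below may be only part of what the source reports. "The series", "measured", "known", "first", "only" and "open" are said of these compounds alone.

Compound 1 `Cn1c(-c2ccccc2Br)cc2cc(CCC(=O)O)ccc21`: > 10000 nM in a functional assay on CHO cells for agonist activity at Free fatty acid receptor 1 (Homo sapiens), read by a luciferase reporter, with a stated time of 24 h (on this read-out lower numbers stand for an effect already at smaller amounts and higher numbers for an effect only at larger amounts of compound), a limit of the assay.
Compound 2 `O=C(O)CCc1ccc2[nH]c(-c3ccccc3C(F)(F)F)cc2c1`: 1310 nM in this assay.

Among the measured compounds shown here, compound 2 holds the only number measured in this assay. The value of compound 1 is a limit, (the limit of > 10000 nM in this assay, at which 1 of the 2 values shown sits). For the measured compounds named here, no step between two measured compounds exists, so compound 2 has no sized neighbour. Compound 3 `CC(C)c1ccccc1-c1cc2cc(CCC(=O)O)ccc2[nH]1` differs from compound 2 by isopropyl in place of trifluoromethyl on an aromatic carbon. For this change the step is expected to stay within the usual scatter, with no set direction. The expected step is a 1.1-fold higher number from compound 2 to compound 3 (0.06 log units; within the scatter). Compound 3 is estimated at 1500 nM in this assay, range 500 nM to 4500 nM.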

Compound 3, half-maximal effective concentration: > 25 nM
Compound 3: no number, only a limit; the forecaster's own chance of this, stated with the estimate: 10%; the middle value does not contradict the limit.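

In this assay, among the compounds shown here, compound 3 gives only a limit (> 25 nM), so no step from compound 2 to compound 3 can be read. Still open, as far as these compounds go, is what isopropyl in place of trifluoromethyl does to the half-maximal effective concentration.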